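Chloro for Hydrogen: From Compound 1 to Compound 3

The source may report more compounds than this note shows. Statements on the series, on what has been measured and on what is new or still open speak of the compounds shown alone.

Measured so far:
compound 1 `CCn1cc(-c2nc3ccccc3[nH]2)c(=O)c2cc(F)c(N3CCNCC3)cc21` — > 10000 nM
compound 2 `CCn1cc(-c2nc3ccccc3[nH]2)c(=O)c2cc(F)c(N3CCNCC3)nc21` — 9100 nM

Of the compounds shown here, two have been tested in a functional assay on HepG2 cells (Homo sapiens) for cytotoxicity, read by sulforhodamine B assay, with a stated time of 48 h; a lower number here means a stronger inhibitor, a higher number a weaker inhibitor. Compound 1 yields no number in this assay but only a limit, > 10000 nM. Compound 2 gives 9100 nM in this assay. Going by the values given here, both values lie at the weak end of what the assay can report, and no step between the two is given here. Where compound 1 stands is told by the limit of > 10000 nM in this assay, at which 1 of the 2 values shown sits, so its true value is unknown beyond that boundary.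

Compound 3 `CCn1cc(-c2nc3ccc(Cl)cc3[nH]2)c(=O)c2cc(F)c(N3CCNCC3)cc21` has not yet been measured. It differs from compound 1 by chloro in place of hydrogen on an aromatic carbon, a change confined to the 1H-benzimidazol-2-yl group. Nothing among the tested compounds shows what a chloro in place of hydrogen at this position does, so the step in this assay is expected to be small, within the usual scatter, with no clear direction. The estimate for compound 3 is 10000 nM, within a range from 3000 nM to 30000 nM. The expected step from compound 1 to compound 3 is a number no higher from compound 1 to compound 3 (the limit leaves the size open).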

Compound 3, half-maximal inhibitory concentration: 3700 nM
Beside the measured number, compound 3's estimate is 2.7-fold (0.43 log units) above it; measured number inside the range.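

In this assay, chloro in place of hydrogen on an aromatic carbon of the 1H-benzimidazol-2-yl group gives an at least 2.7-fold lower number from compound 1 to compound 3 (0.43 log units; beyond the scatter). Going by these compounds alone, this is the first evidence that this position is not silent: the earlier compounds did not differ there, yet here a change of a single heavy atom, made in the 6-chloro-1H-benzimidazol-2-yl group, moves the number beyond the scatter and towards stronger inhibition. The value of compound 1 is a limit and not a number, so only a lower bound on the size of this step can be given, because compound 1 has no exact value to measure it from: the limit of > 10000 nM in this assay, at which 1 of the 3 values shown sits.

The compounds shown leave open whether chloro itself matters at this carbon or whether another group there, such as fluoro, methyl, methoxy or an amine, would lower the number as well. They also leave open whether chloro on another carbon of that six-membered ring would do the same, and whether this chloro would have a like effect on the core of compound 2.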